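The source may report more compounds than this note shows. Statements on the series, on what has been measured and on what is new or still open speak of the compounds shown alone.

Compound 1 `COc1ccc(-c2cc(=O)c3c(OC)cc(OC)cc3n2S(=O)(=O)c2c(F)c(F)c(F)c(F)c2F)cc1`: > 34400 nM
Compound 2 `COc1cc(OC)c2c(=O)cc(C(=O)Nc3cc(C(F)(F)F)ccc3Oc3ccccc3OC)[nH]c2c1`: > 53400 nM

In a functional assay on KOPN-8 cells (Homo sapiens) for antiproliferative activity, with a stated time of 72 h (on this read-out higher numbers stand for an effect only at larger amounts of compound and lower numbers for an effect already at smaller amounts), compound 1 gives only a limit, > 34400 nM, and not a number. Compound 2 likewise gives only a limit, > 53400 nM. Compound 2 therefore stands at the limit of > 53400 nM in this assay, at which 1 of the 2 values shown sits, so nothing more than that can be said of its place. Compound 3 `COc1ccc(Oc2ccc(C(F)(F)F)cc2NC(=O)c2cc(=O)c3c(OC)cc(OC)cc3[nH]2)cc1` differs from compound 2 by 4-methoxyphenyl in place of 2-methoxyphenyl on an oxygen on an aromatic ring. For the measured compounds named here, no step between measured compounds is known, so the expected step that the limit leaves unreadable from compound 2 to compound 3 is none beyond the usual scatter. Compound 3 is expected to give 60000 nM, within 20000 nM to 200000 nM.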

Compound 3, half-maximal effective concentration: > 67200 nM
Compound 3: no number, only a limit (the forecaster's own chance of this, stated with the estimate: 85%); middle value at least 1.1-fold (0.04 log units) from the limit.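

Compound 2 and compound 3 each give only a limit in this assay, so the change from 2-methoxyphenyl to 4-methoxyphenyl yields no readable step. From the compounds shown here alone, whether compound 1, compound 2 or compound 3 stops these cells growing at any measurable amount stays open.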